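From Diisopropylamino to a Silicon-Bearing Group

The source may hold more compounds than are shown below. What is called first, only, known or untested is meant among the compounds shown, and "the series" means these compounds.

Compound 1 `CC(=O)OC/C1=C/C[C@](C)(CCC=C(C)C)/C=C/[C@@H](OC(=O)C=C(C)C)[C@](C)(O)/C=C/C1=O` in a functional assay on MCF7 cells (Homo sapiens) for antiproliferative activity, read by MTT assay, with a stated time of 48 h; a lower number here means a stronger inhibitor, a higher number a weaker inhibitor: 4510 nM
Compound 2 `CC(C)=CCC[C@]1(C)/C=C/[C@@H](OC(=O)C=C(C)C)[C@](C)(O)/C=C/C(=O)/C(CN(C)C)=C\C1` in this assay: 690 nM
Compound 3 `CC(C)=CCC[C@]1(C)/C=C/[C@@H](OC(=O)C=C(C)C)[C@](C)(O)/C=C/C(=O)/C(CN(C(C)C)C(C)C)=C\C1` in this assay: 780 nM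

On these numbers, compound 3 cannot be told apart from its dimethylamino partner, with a 1.1-fold higher number from compound 2 to compound 3 (0.05 log units; within the scatter). It stands clearly apart from the acetoxy compound, with a 5.8-fold lower number from compound 1 to compound 3 (0.76 log units; beyond the scatter).

The next compound, compound 4 `CC[Si](CC)(CC)C/C1=C/C[C@](C)(CCC=C(C)C)/C=C/[C@@H](OC(=O)C=C(C)C)[C@](C)(O)/C=C/C1=O`, has yet to be measured in this assay. Its difference from compound 3 is a group of 7 heavy atoms (6 carbon, 1 silicon; no ring) in place of a group of 7 heavy atoms (6 carbon, 1 nitrogen; no ring), on a saturated chain carbon bound to a double-bonded ring carbon. Diisopropylamino leaves, and the entering group has no common name. The change lies on a saturated chain carbon bound to a double-bonded ring carbon.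

Going by the values given here, no measured step introduces silicon, so the evidence is indirect. Replacing acetoxy with dimethylamino gave a 6.5-fold lower number from compound 1 to compound 2 (0.82 log units; beyond the scatter), and the diisopropylamino replacement was of similar, modest size. Compound 1, which has no amino group at this place, stands at 4510 nM. Going by these compounds, compound 4 also lacks an amino group there, so a modest move towards a higher number is expected in this assay, though how far it goes remains open.

The expected change is a 2.3-fold higher number from compound 3 to compound 4 (0.36 log units; beyond the scatter). For compound 4, the estimated value is 1800 nM, with an expected range from 600 nM to 5500 nM.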

Compound 4, half-maximal inhibitory concentration: 3150 nM
Estimate against measurement, compound 4: 1.8-fold (0.24 log units) below, within the range that was stated.
By their numbers in this assay, from the lowest: compounds 2 and 3 (each within the scatter of the next); then compounds 4 and 1 (each within the scatter of the next).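

In this assay, the silicon-bearing group does not keep the level reached with the amines (a 4.0-fold higher number from compound 3 to compound 4 (0.61 log units; beyond the scatter); a 4.6-fold higher number from compound 2 to compound 4 (0.66 log units; beyond the scatter)), even though it has the same heavy-atom count as diisopropylamino and differs from it by silicon in place of nitrogen. Compound 4 cannot be told apart from the acetoxy compound (a 1.4-fold lower number from compound 1 to compound 4 (0.16 log units; within the scatter)), so the four compounds fall into two pairs: compounds 2 and 3, with an amino group on the saturated chain carbon bound to a double-bonded ring carbon, give the lower numbers, while compounds 1 and 4, without one, give the higher numbers, and no compound shown goes against this. Group size alone does not sort these results, since dimethylamino and diisopropylamino stand together while the two groups of 7 heavy atoms stand apart.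

Nothing given here accounts for this split between the pairs. Going by these compounds, it remains open whether a piperidine, a morpholine or a primary amine at this place would stand with compounds 2 and 3, and whether a trimethylsilyl group would stand with compounds 1 and 4.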